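Swapping fluoro for hydroxy: effect on cell tolerance

The source may report more compounds than this note shows. Statements on the series, on what has been measured and on what is new or still open speak of the compounds shown alone.

Measured so far:
compound 1, `Cc1cc(-c2cccc(F)c2)c2ncc(CSCCc3ccccc3)n2c1`, 20 ug/mL
compound 2, `Cc1cc(-c2cccc([N+](=O)[O-])c2)cn2c(CSCCc3ccccc3)cnc12`, >= 100 ug/mL

Among the compounds with values here, compound 1 is the only compound with a numeric value in an ADME assay on HEL cells (Homo sapiens) for cytotoxicity, with a stated time of 3 days; a lower number here means that less compound is tolerated, a higher number that more compound is tolerated. Compound 2 sits at a limit of this assay, (the limit of >= 100 ug/mL in this assay, at which 1 of the 2 values shown sits), not at a number. Compound 3, `Cc1cc(-c2cccc(O)c2)c2ncc(CSCCc3ccccc3)n2c1`, remains to be tested. It differs from compound 1 by hydroxy in place of fluoro on an aromatic carbon. Within the data shown here, with no comparable step measured, the step of a 2.3-fold higher number from compound 1 to compound 3 (0.35 log units; beyond the scatter) is expected to be modest, toward more compound tolerated, and may not exceed the scatter. Compound 3 is estimated at 45 ug/mL, within 20 ug/mL to 100 ug/mL.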

Compound 3, minimum cytotoxic concentration: 20 ug/mL
For compound 3 the middle estimate is 2.3-fold (0.35 log units) above the measured one; low and high end bracket the measured number.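

In this assay, hydroxy in place of fluoro gives no change at the digits printed from compound 1 to compound 3 (within the scatter), the only step shown at this position. Bringing in a hydrogen-bond donor and acceptor on this aromatic carbon, meta to a large group, therefore makes no readable difference to how much compound the cells tolerate. Nothing shown here offers a reason for this result. As far as these compounds go, whether an amine or a carboxylic acid at this position would give the same result stays open. Compound 2 differs from compound 1 in more than one place, so it cannot answer that.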